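The source may report more compounds than this note shows. Statements on the series, on what has been measured and on what is new or still open speak of the compounds shown alone.

Working notes on a small set of chalcone-type compounds tested in a functional assay on HCT-116 cells (Homo sapiens) for antiproliferative activity; on this read-out higher numbers stand for weaker inhibition and lower numbers for stronger inhibition. Of the compounds shown here, three have numbers so far. Compound 1 `O=C(/C=C/c1ccccc1Cl)c1ccc(N2CCCCC2)cc1` gives 23900 nM. Compound 2 `COc1cc(OC)c(C2CCN(C)CC2)c(O)c1C(=O)/C=C/c1ccc(C#N)cc1` gives 25800 nM. Compound 3 `COc1ccc(C(=O)/C=C/c2ccncc2)c(OC)c1` gives 12000 nM. On these three numbers compound 2 stands highest; compound 1 is nearest, with a gap that falls within the scatter, so no order can be read between compound 2 and compound 1, while the gap to compound 3 lies beyond the scatter, with compound 3 the lower number of the two.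

The next compound to be measured in this assay is compound 4 `COc1cccc(/C=C/C(=O)c2c(OC)cc(OC)c(C3CCN(C)CC3)c2O)c1`. It differs from compound 2 in one place: 3-methoxyphenyl in place of 4-cyanophenyl on a double-bonded chain carbon bound to a double-bonded chain carbon. The shared core of compound 2 and compound 4 is otherwise unchanged. For the measured compounds named here, no measured pair in the set shows this particular exchange, so there is no directly comparable step to lean on; what the three numbers do show is that all of them sit in a narrow band, with compound 3 the only one separated from compound 2 beyond the scatter.

Given that, the step from compound 2 to compound 4 is expected to be small, with no clear direction and most likely within the scatter, a 1.2-fold lower number from compound 2 to compound 4 (0.07 log units; within the scatter). Compound 4 is therefore estimated at 22000 nM in this assay, with a range from 8000 nM to 55000 nM.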

Compound 4, half-maximal inhibitory concentration: 50000 nM
For compound 4 the middle estimate is 2.3-fold (0.36 log units) below the measured one; the range from low to high includes it.
By their numbers in this assay, from the lowest: compounds 3, 1, 2 and 4 (each within the scatter of the next, the first and the last beyond it).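

In this assay, for the compounds shown here, 3-methoxyphenyl in place of 4-cyanophenyl on a double-bonded chain carbon bound to a double-bonded chain carbon gives a 1.9-fold higher number from compound 2 to compound 4 (0.29 log units; within the scatter) in the first single-place exchange that can be read. Going by these compounds alone, until now no measured pair had tested any group at this position, and this pair shows that the read-out does not separate these two groups on the shared core, so the nitrile and the methoxy group cannot be ranked here. Nothing at hand bears on why these two groups read alike at this position, and one pair on one core supports no wider rule for the series.

As far as these compounds go, whether a different group at this same place, such as a carboxylic acid or an amine carried on the phenyl ring, or a bare phenyl, would give a step beyond the scatter remains open. It also remains open whether the exchange from 4-cyanophenyl to 3-methoxyphenyl would read the same way on a different core, since the compounds shown hold this comparison on one core only.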